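Cytotoxicity notes: new group on the aromatic nitrogen

The source may hold more compounds than are shown below. What is called first, only, known or untested is meant among the compounds shown, and "the series" means these compounds.

For the measured compounds named here, compound 1 `CCOC(=O)C1=C(C)N/C(=C/c2cc(C)n(-c3cccc(C(F)(F)F)c3)c2C)C1=O` in an ADME assay on L6 cells (Rattus norvegicus) for cytotoxicity, read by resazurin assay, with a stated time of 72 h (on this read-out lower numbers stand for an effect already at smaller amounts and higher numbers for an effect only at larger amounts of compound), gives 100000 nM, the second highest of the three numbers measured so far. Its nearest neighbour is compound 3 `CCOC(=O)C1=C(C)N/C(=C/c2cc(C)n(-c3cccc(O)c3)c2C)C1=O`, which in this assay gives 69000 nM; the furthest is compound 2 `CCOC(=O)C1=C(C)N/C(=C/c2cc(C)n(-c3ccc(N(C)C)cc3)c2C)C1=O`, which in this assay gives 180000 nM. The measured steps are a 1.8-fold higher number from compound 1 to compound 2 (0.26 log units; within the scatter), a 1.4-fold lower number from compound 1 to compound 3 (0.16 log units; within the scatter) and a 2.6-fold lower number from compound 2 to compound 3 (0.42 log units; beyond the scatter).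

Compound 4 `CCOC(=O)C1=C(C)N/C(=C/c2cc(C)n(-c3ccc(SC)cc3)c2C)C1=O` is not yet measured. It differs from compound 1 as follows: 4-(methylsulfanyl)phenyl in place of 3-(trifluoromethyl)phenyl on an aromatic nitrogen. Going by the values given here, the steps that bear on this change are the exchange of the whole group on the aromatic nitrogen, a 1.8-fold higher number from compound 1 to compound 2 (0.26 log units; within the scatter), and the exchange of a substituent on that group, a 1.4-fold lower number from compound 1 to compound 3 (0.16 log units; within the scatter); both stay within the scatter. Among the compounds with values here, only the pair of compounds 2 and 3 shows a modest step, and neither of these carries the group entering in compound 4. The step from compound 1 to compound 4 in this assay is therefore expected to be a 1.1-fold higher number from compound 1 to compound 4 (0.04 log units; within the scatter), with no clear direction. Compound 4 is estimated to give 110000 nM, in the range 55000 nM to 220000 nM.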

Compound 4, half-maximal effective concentration: 54000 nM
The estimate for compound 4 lay 2.0-fold (0.31 log units) above the measured number, outside the stated range (below it).
By their numbers in this assay, from the lowest: compounds 4, 3, 1 and 2 (each within the scatter of the next, the first and the last beyond it).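

On the aromatic nitrogen, 4-(methylsulfanyl)phenyl in place of 3-(trifluoromethyl)phenyl gives a 1.9-fold lower number from compound 1 to compound 4 (0.27 log units; within the scatter), and its exchange for 3-hydroxyphenyl gives a 1.3-fold lower number from compound 3 to compound 4 (0.11 log units; within the scatter), so neither step separates these groups in this assay. The clearer contrast lies in the substituent on the aromatic carbon: methylsulfanyl in place of dimethylamino gives a 3.3-fold lower number from compound 2 to compound 4 (0.52 log units; beyond the scatter), which makes compound 4 the second compound whose step from compound 2 lies beyond the scatter, although compound 1 stays within the scatter of compound 2. No measurement is at hand that accounts for this step.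

Open, going by these compounds, is whether dimethylamino itself sets compound 2 apart, or whether a 4-methoxyphenyl or 4-carboxyphenyl group on the aromatic nitrogen would read alongside it. Also open, on these data alone, is how 3-(methylsulfanyl)phenyl would compare with 4-(methylsulfanyl)phenyl in this assay.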